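From nitrooxy to hydroxy on compound 2

The compounds below may be only part of what the source reports. "The series", "measured", "known", "first", "only" and "open" are said of these compounds alone.

In a functional assay on SK-BR-3 cells (Homo sapiens) for antiproliferative activity, read by CCK-8 assay and cell counting, with a stated time of 72 h (a lower number here means a stronger inhibitor, a higher number a weaker inhibitor), compound 1 (`O=C(Nc1ccccc1OC(=O)c1ccc(CCl)cc1)c1ccc(CCl)cc1`) gives 600 nM and compound 2 (`O=C(Nc1ccccc1)c1ccc(CO[N+](=O)[O-])cc1`) gives 700 nM as its reading, two values within the scatter of each other. Compound 3 (`O=C(Nc1ccccc1)c1ccc(CO)cc1`) has hydrogen in place of nitro on an oxygen on a saturated carbon, which turns nitrooxy into hydroxy. Among the compounds with values here, no measured pair shows this change, so the expectation rests on the structural change alone: a clear step in this assay toward a higher number, meaning a weaker inhibitor. The expected size is a 4.3-fold higher number from compound 2 to compound 3 (0.63 log units; beyond the scatter) and remains uncertain. Compound 3 is estimated at 3000 nM with an expected range from 800 nM to 12000 nM in this measurement.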

Compound 3, half-maximal inhibitory concentration: 9800 nM
Compound 3: the middle estimate sits 3.3-fold (0.51 log units) below what was measured; the measured number falls inside the stated range.
By their numbers in this assay, from the lowest: compounds 1 and 2 (each within the scatter of the next); then compound 3.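

In this assay, within the data shown here, the change of nitrooxy to hydroxy gives a 14-fold higher number from compound 2 to compound 3 (1.15 log units; beyond the scatter) and is the first single change measured in this set. It shows that the reading at this place depends strongly on which of these two groups stands there, which the comparison of compound 1 and compound 2 could not show. Nothing given here bears on what lies behind this step.

The compounds shown leave open whether an amine or a methoxy group in place of the nitrooxy group would read nearer compound 2 or compound 3. They also leave open whether a longer chain carrying the nitrooxy group would keep the reading of compound 2.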